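Adding Fluorine to the Benzyl Arm of Compound 2

The compounds below may be only part of what the source reports. "The series", "measured", "known", "first", "only" and "open" are said of these compounds alone.

Compound 1 `COc1ccc(-c2nn(-c3ccccc3)cc2C(=O)NOCc2ccccc2F)cc1` and compound 2 `O=C(NOCc1ccccc1)c1cn(-c2ccccc2)nc1-c1ccc(Cl)cc1` share one core and differ in two places. In a functional assay on A549 cells (Homo sapiens) for antiproliferative activity, read by MTT assay, with a stated time of 48 h, in the presence of a further agent that is not named here (on this read-out lower numbers stand for stronger inhibition of growth and higher numbers for weaker inhibition of growth), compound 1 gives 2160 nM and compound 2 gives 13000 nM, the higher of the two numbers, a gap beyond the scatter. Compound 3 `O=C(NOCc1ccccc1F)c1cn(-c2ccccc2)nc1-c1ccc(Cl)cc1` is compound 2 with a single change: fluoro in place of hydrogen on an aromatic carbon. Going by the values given here, no measured pair isolates this change, since compound 1 also differs from compound 2 elsewhere. A modest move toward stronger inhibition is expected for compound 3, the step of a 1.6-fold lower number from compound 2 to compound 3 (0.21 log units; within the scatter) perhaps no larger than the scatter. The estimate for compound 3 in this assay is 8000 nM, within 3000 nM to 20000 nM.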

Compound 3, concentration for 50% growth inhibition: 12100 nM
Beside the measured number, compound 3's estimate is 1.5-fold (0.18 log units) below it; low and high end bracket the measured number.
By their numbers in this assay, from the lowest: compound 1; then compounds 3 and 2 (each within the scatter of the next).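

In this assay fluoro in place of hydrogen on the benzyl arm gives a 1.1-fold lower number from compound 2 to compound 3 (0.03 log units; within the scatter) so benzyl and 2-fluorobenzyl cannot be told apart while chloro is present. With 2-fluorobenzyl held constant, chloro in place of methoxy gives a 5.6-fold higher number from compound 1 to compound 3 (0.75 log units; beyond the scatter) and this isolates a change beyond the scatter. Nothing measured here explains either result.

An amine or a carboxylic acid at the fluoro position might behave differently. On these data alone, whether fluoro matters when methoxy replaces chloro also stays open.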